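A few compounds are considered here, and "the series" means these few. Any claim that something is new, unique, unknown or untested is made for them only; others in the source may bear on it.

Measured compounds: compound 1 `COc1ccc(-c2ccc3c(NCCCNCc4cccc(OC)c4O)ccnc3c2)cc1` 237 10^-6 cm/s; compound 2 `CC(C)Cc1ccc2c(NCCCNCc3ccco3)ccnc2c1` 23 10^-6 cm/s; compound 3 `COc1ccc(Oc2ccc3c(NCCCNCc4cccc(OC)c4O)ccnc3c2)cc1` 317 10^-6 cm/s.

In an ADME assay for permeability, using PAMPA, with a stated time of 30 min, at pH 7.4 (on this read-out lower numbers stand for lower permeability and higher numbers for higher permeability), compound 2 gives the lowest of the three numbers, well below compound 1 and compound 3. Going by the values given here, the single measured step, a 1.3-fold higher number from compound 1 to compound 3 (0.13 log units; within the scatter), lies within the scatter and swaps one aromatic group for another, so it says little about the step from compound 2 to compound 4 `Fc1ccc(Cc2ccc3c(NCCCNCc4ccco4)ccnc3c2)c(Cl)c1`, which introduces (2-chloro-4-fluorophenyl in place of isopropyl on a saturated chain carbon bound to an aromatic carbon). Compounds 1 and 3 both carry an aromatic group on the shared core and sit high; compound 2, with an isobutyl there, sits low. On that basis compound 4 is expected to move upward, by about a 4.3-fold higher number from compound 2 to compound 4 (0.64 log units; beyond the scatter) in this assay, though the gap is uncertain. Compound 4 is therefore estimated at 100 10^-6 cm/s, with a range from 35 10^-6 cm/s to 280 10^-6 cm/s.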

Compound 4, apparent permeability: 23 10^-6 cm/s
For compound 4 the middle estimate is 4.3-fold (0.64 log units) above the measured one; the whole stated range lies above it.
By their numbers in this assay, from the lowest: compounds 2 and 4 (each within the scatter of the next); then compounds 1 and 3 (each within the scatter of the next).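

In this assay the change from isobutyl to 2-chloro-4-fluorobenzyl gives no change at the digits printed from compound 2 to compound 4 (within the scatter) on this read-out. At this place, then, a group of eight heavy atoms with an aromatic ring replaces one of three heavy atoms without moving the number beyond the scatter. No measurement shown explains this result.

Going by these compounds, whether a carboxylic acid at this place would shift the number remains open. So does whether a plain benzyl, without chlorine or fluorine, would behave like 2-chloro-4-fluorobenzyl.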